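The source may hold more compounds than are shown below. What is called first, only, known or untested is meant among the compounds shown, and "the series" means these compounds.

Measured so far:
compound 1 `CCc1ccc2nc(C(=O)Nc3c(F)cc(-c4cccc(F)c4)cc3F)c(C)c(O)c2c1` gives -0.35%
compound 2 `Cc1ccc2nc(C(=O)Nc3c(F)cc(-c4cccc(F)c4)cc3F)c(C)c(C(=O)O)c2c1` gives -1.05%

Both compounds were tested in a functional assay on A-375 cells (Homo sapiens) for antiproliferative activity, read by MTT assay, with a stated time of 24 h, tested at 0.01 ug/mL; a lower number here means a weaker effect, a higher number a stronger effect of the compound at the concentration tested. Compound 1 gives -0.35% and compound 2 gives -1.05%. Compound 2 stands with the lower of the two numbers, but the gap to compound 1 lies within the scatter of this assay, so the two cannot be told apart: each shows essentially no effect at the concentration tested. The two compounds differ in more than one place, so nothing about what a single structural change does to this read-out can be read from them.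

Compound 3 `CCc1ccc2nc(C(=O)Nc3c(F)cc(-c4cccc(F)c4)cc3F)c(C)c(C(=O)O)c2c1` has not yet been measured. It differs from compound 2 by methyl in place of hydrogen on a saturated chain carbon bound to an aromatic carbon; the rest of the molecule is kept. With compound 1 at -0.35% and compound 2 at -1.05%, no movement beyond the scatter is expected in this assay, and the step of a number 0.6 percentage points higher from compound 2 to compound 3 (within the scatter) is estimated to be negligible. Compound 3 is therefore expected to give about -0.5%, with an estimated range from -10% to 9%.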

Compound 3, a percentage reported as inhibition, at one concentration (the size of the read-out at that concentration, not a potency): -0.45%
Compound 3: the middle estimate sits 0.1 percentage points below what was measured; the measured number falls inside the stated range.
By their numbers in this assay, from the lowest: compounds 2, 3 and 1 (each within the scatter of the next).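

In this assay, the move from methyl to ethyl, which puts methyl in place of hydrogen on a saturated chain carbon bound to an aromatic carbon, gives a number 0.6 percentage points higher from compound 2 to compound 3 (within the scatter) and so leaves no readable change at this place. Carboxy in place of hydroxy on an aromatic carbon gives a number 0.1 percentage points lower from compound 1 to compound 3 (within the scatter) and is equally unreadable, so compound 3 now joins the two earlier compounds through two single changes, neither of which separates the compounds it connects. All three compounds stay close to no effect at the one concentration tested, and no measurement that could explain this is available here.

On these data alone, what remains open is whether either change would show an effect at a concentration where these compounds act at all, as this single read-out cannot tell a change with no influence from one that stays hidden. Also unresolved is how a longer chain such as propyl at the ethyl place, or an amine in place of the carboxy group on the aromatic carbon, would behave.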